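Benzofuran series: liver microsome stability, step to the phenol

The source may hold more compounds than are shown below. What is called first, only, known or untested is meant among the compounds shown, and "the series" means these compounds.

Three compounds of a shared core have been run in an ADME assay on microsomes from liver (Rattus norvegicus) for metabolic stability, with a stated time of 10 min; on this read-out lower numbers stand for a less stable compound and higher numbers for a more stable compound. Compound 1 `COc1cc(OCc2ccccc2OC)c2cc(-c3cn4nc(OC)sc4n3)oc2c1` gives 28% in this assay. Compound 2 `CCSc1nn2cc(-c3cc4ccccc4o3)nc2s1` gives 35%. Compound 3 `COc1cc(OCc2cccc(COc3ccccc3)c2)c2cc(-c3cn4nc(OC)sc4n3)oc2c1` gives 64%, the highest of the three numbers; its nearest neighbour is compound 2, lower by a margin beyond the scatter, and the furthest is compound 1, lower by a still larger margin, also beyond the scatter. No two of the measured compounds differ in a single place, so no single-point step can be read from them.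

Compound 4 `COc1cc(OCc2cccc(O)c2)c2cc(-c3cn4nc(OC)sc4n3)oc2c1` is the next entry. Relative to compound 3 the change is hydroxy in place of phenoxymethyl on an aromatic carbon — hydroxy in place of phenoxymethyl on an aromatic carbon, meta to a large group. Within the data shown here, no measured pair mirrors this change. A drop in this assay is expected, of moderate size, because compound 1, which also carries no phenoxymethyl, sits at 28%. Compound 4 is therefore estimated at 40%, with a range from 20% to 62%. The expected step is a number 24 percentage points lower from compound 3 to compound 4 (beyond the scatter).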

Compound 4, percent of the compound remaining: 49%
For compound 4 the middle estimate is 9 percentage points below the measured one; low and high end bracket the measured number.
By their numbers in this assay, from the lowest: compounds 1 and 2 (each within the scatter of the next); then compound 4; then compound 3.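

In this assay, among these compounds, hydroxy in place of phenoxymethyl on this aromatic carbon gives a number 15 percentage points lower from compound 3 to compound 4 (beyond the scatter) and so costs part of the stability, though not all of it. 3-Hydroxyphenyl in place of 2-methoxyphenyl gives a number 21 percentage points higher from compound 1 to compound 4 (beyond the scatter) as a step in the opposite direction, which makes compound 4 the first compound with a single-place comparison on each side. Nothing shown accounts for either step.

A 3-methoxyphenyl or 2-hydroxyphenyl group would be needed to separate the exchange of methoxy for hydroxy from the shift in where the group sits on the ring. As far as these compounds go, it also remains open whether a methoxy, an amine or a carboxylic acid on the carbon that carries hydroxy in compound 4 would fall nearer compound 3 or compound 4.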